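Taking the Chlorine Off Compound 2

The source may report more compounds than this note shows. Statements on the series, on what has been measured and on what is new or still open speak of the compounds shown alone.

Two chlorinated compounds have been measured so far. In a functional assay on PANC-1 cells (Homo sapiens) for inhibition, read by MTT assay, with a stated time of 24 h (a higher number here means a weaker inhibitor, a lower number a stronger inhibitor), compound 1 `CC1(C)[C@H]2CC[C@]1(C)N(Cc1cn(-c3ccccc3Cl)nn1)C(=O)C2` gives 270 nM, and compound 2 `CC1(C)[C@H]2CC[C@]1(C)N(Cc1cn(-c3cccc(Cl)c3)nn1)C(=O)C2` gives 260 nM. Compound 2 therefore stands level with compound 1, since the two numbers lie within the scatter of repeated measurements.

The next compound, compound 3 `CC1(C)[C@H]2CC[C@]1(C)N(Cc1cn(-c3ccccc3)nn1)C(=O)C2`, has hydrogen in place of chloro on an aromatic carbon, turning the 3-chlorophenyl group into a plain phenyl group: hydrogen in place of chloro on an aromatic carbon.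

Among the measured compounds shown here, only one measured step bears on this change, and it bears only indirectly. Shifting the chlorine gave a 1.0-fold lower number from compound 1 to compound 2 (0.02 log units; within the scatter), so its position made no measurable difference in this assay. For the measured compounds named here, that step does not test losing the chlorine altogether, and no compound without it has been measured yet. With no evidence for a direction, no change beyond the scatter is expected, though the range must stay wide. The expected step is a 1.2-fold higher number from compound 2 to compound 3 (0.06 log units; within the scatter). For compound 3 the estimated value is 300 nM, with an expected range of 130 nM to 700 nM.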

Compound 3, half-maximal inhibitory concentration: 160 nM
For compound 3 the middle estimate is 1.9-fold (0.27 log units) above the measured one, and the stated range covers the measured number.
By their numbers in this assay, from the lowest: compounds 3, 2 and 1 (each within the scatter of the next).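

Losing the chlorine altogether can now be read directly. In this assay the change from 3-chlorophenyl to phenyl gives a 1.6-fold lower number from compound 2 to compound 3 (0.21 log units; within the scatter) and the change from 2-chlorophenyl to phenyl gives a 1.7-fold lower number from compound 1 to compound 3 (0.23 log units; within the scatter) and so neither step can be told apart from repeat-measurement noise. The earlier compounds showed only that moving the chlorine made no measurable difference, whereas these steps show that a chlorine at either of these two places is not needed for a number in this range, and no available data explain why swapping it for hydrogen leaves the result within the scatter.

What the compounds shown leave open is whether this part of the molecule tolerates any replacement, or only the small swap between chloro and hydrogen. A methoxy group, an amine or a carboxylic acid on the same aromatic ring could still move the number beyond the scatter, and only such a compound, compared with compound 3 and differing in that one place, would tell.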